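Replacing methoxycarbonyl with hydroxymethyl in compound 1

The source may report more compounds than this note shows. Statements on the series, on what has been measured and on what is new or still open speak of the compounds shown alone.

Among the measured compounds shown here, in a functional assay on DU-145 cells (Homo sapiens) for cytotoxicity, read by MTT assay (on this read-out higher numbers stand for weaker inhibition and lower numbers for stronger inhibition), compound 1 `COC(=O)C[C@@H]1C[C@@H](O)[C@H](C)[C@H](c2ccccc2)N1` gives 6300 nM, the lowest number measured so far. Compound 2 `COC(=O)C[C@H]1C[C@@H](O)[C@H](C)[C@@H](c2ccccc2)N1` gives 64100 nM. Compound 3 `COC(=O)C[C@H]1C[C@H](O)[C@H](C)[C@@H](c2ccccc2)N1` is reported as "not active" (no number reported), with no number. The large step of a 10-fold higher number from compound 1 to compound 2 (1.01 log units; beyond the scatter) goes back to the fact that compounds 1 and 2 differ only in the configuration as drawn, and compound 3 stands apart through (the fact that compounds 1 and 3 differ only in the configuration as drawn).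

Compound 4 `C[C@H]1[C@H](O)C[C@@H](CCO)N[C@H]1c1ccccc1` has not yet been measured. It carries this change: hydroxymethyl in place of methoxycarbonyl on a saturated chain carbon bound to a saturated ring carbon. In short, hydroxymethyl sits in place of methoxycarbonyl on a saturated chain carbon bound to a saturated ring carbon. The measured steps concern configuration only, so none of them tests this swap directly. They do show that numbers on this core can move a long way, as in a 10-fold higher number from compound 1 to compound 2 (1.01 log units; beyond the scatter). A moderate move toward a higher number, meaning weaker inhibition, is therefore expected, with wide uncertainty. The expected step is a 1.9-fold higher number from compound 1 to compound 4 (0.28 log units; within the scatter). For compound 4 the estimated value is 12000 nM, within an expected range of 2500 nM to 60000 nM.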

Compound 4, half-maximal inhibitory concentration: 41600 nM
For compound 4 the middle estimate is 3.5-fold (0.54 log units) below the measured one; the range from low to high includes it.
By their numbers in this assay, from the lowest: compound 1; then compounds 4 and 2 (each within the scatter of the next).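

In this assay, this is the first change shown that replaces a group instead of altering configuration, and it has a clear effect on a saturated chain carbon bound to a saturated ring carbon: a 6.6-fold higher number from compound 1 to compound 4 (0.82 log units; beyond the scatter). The step lies beyond the usual scatter, so on the core of compound 1, hydroxymethyl in place of methoxycarbonyl means weaker inhibition on this read-out, though the loss is modest. Nothing measured here explains this step, since the available comparisons concern configuration alone.

From the compounds shown here alone, a single swap cannot show which part of methoxycarbonyl matters, so it remains open whether a carboxylic acid, an amine or a longer chain at this place would give a lower or a higher number. Going by these compounds, it also remains open whether the same swap would produce a step of similar size in the configuration of compound 2.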